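The source may report more compounds than this note shows. Statements on the series, on what has been measured and on what is new or still open speak of the compounds shown alone.

In an assay on isolated protein for inhibition of MAP kinase-activated protein kinase 5 (Homo sapiens), read by mobility shift assay, tested at 30 uM (a lower number here means less inhibition, a higher number more inhibition at the concentration tested (going by the name of the read-out)), compound 1 `CC(C)(C)c1cc2nn(-c3ccccc3)c(N)c2c(=O)[nH]1` gives 2% and compound 2 `Nc1c2c(=O)[nH]c(-c3ccccc3)cc2nn1-c1ccccc1` gives 22%. Among the measured compounds shown here, the one measured step, a number 20 percentage points higher from compound 1 to compound 2 (beyond the scatter), follows phenyl in place of tert-butyl on an aromatic carbon. On these two numbers compound 2 stands highest, with compound 1 the nearest and lower by a margin beyond the scatter.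

Compound 3 `COc1ccccc1-c1cc2nn(-c3ccccc3)c(N)c2c(=O)[nH]1` differs from compound 2 in one place: methoxy in place of hydrogen on an aromatic carbon. Read one bond further out, the change is phenyl to 2-methoxyphenyl. For the measured compounds named here, no measured step alters a group on the phenyl itself; the step of a number 20 percentage points higher from compound 1 to compound 2 (beyond the scatter) concerns the exchange of the whole substituent and so bears only loosely on this change. Compound 3 is therefore expected to give about 30% in this assay, within 10% to 55%. That estimate means a step of a number 8 percentage points higher from compound 2 to compound 3 (within the scatter), expected to stay close to the scatter.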

Compound 3, a percentage reported as inhibition, at one concentration (the size of the read-out at that concentration, not a potency): 6%
The estimate for compound 3 lay 24 percentage points above the measured number; the whole stated range lies above it.
By their numbers in this assay, from the lowest: compounds 1 and 3 (each within the scatter of the next); then compound 2.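

Methoxy on the phenyl, ortho to a large group, is the first change to the phenyl itself, and in this assay it gives a number 16 percentage points lower from compound 2 to compound 3 (beyond the scatter). The gain that came with phenyl therefore does not survive this substitution, and replacing tert-butyl with 2-methoxyphenyl gives only a number 4 percentage points higher from compound 1 to compound 3 (within the scatter), so compound 3 cannot be told apart from compound 1 here. Nothing available explains why this single substitution lowers the number.

The compounds shown leave open whether the drop belongs to methoxy itself or would follow any group at this place. A fluorine or a methyl at the same place would separate those two readings, and methoxy elsewhere on the phenyl would show how much the place matters.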